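Removing the linker hydroxy from a potent aryloxypropanolamine

The compounds below may be only part of what the source reports. "The series", "measured", "known", "first", "only" and "open" are said of these compounds alone.

Three compounds, compound 1 `CC(C)NCC(O)COc1ccccc1Cc1ccccc1`, compound 2 `C=CCc1cc(C(=O)CCC)ccc1OCC(O)CNC(C)C` and compound 3 `CC(C)NCCCOc1ccc(-c2ccccc2)cc1`, have been tested in an assay for inhibition of squalene synthase (Rattus norvegicus), using microsomes; a higher number here means a weaker inhibitor, a lower number a stronger inhibitor. Compound 1 gives 8800 nM, compound 3 gives 170 nM and compound 2 gives 4.5 nM, the lowest number of the three and the strongest inhibitor among them, its gaps to compound 3 and to compound 1 both lying beyond the scatter. Compound 4 `C=CCc1cc(C(=O)CCC)ccc1OCCCNC(C)C` is not yet measured; it differs from compound 2 by hydrogen in place of hydroxy on a saturated chain carbon bound to two saturated chain carbons. Within the data shown here, no measured pair shows this change, so the size of the step is open. A weakening, moderate but beyond the scatter, is expected, and the step from compound 2 to compound 4 is estimated as a 6.7-fold higher number from compound 2 to compound 4 (0.82 log units; beyond the scatter). In this assay compound 4 is therefore expected to give about 30 nM, within a range from 8 nM to 150 nM.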

Compound 4, half-maximal inhibitory concentration: 1 nM
Estimate against measurement, compound 4: 30-fold (1.48 log units) above; measured number outside the range, below it.
By their numbers in this assay, from the lowest: compound 4; then compound 2; then compound 3; then compound 1.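

Compound 2 does not depend on its hydroxy on this saturated chain carbon in this assay: hydrogen in its place gives a 4.5-fold lower number from compound 2 to compound 4 (0.65 log units; beyond the scatter) and so a modest gain rather than a loss. The one hydrogen-bond donor and acceptor that leave with the hydroxy are therefore not required for strong inhibition in this pair. Nothing measured here bears on the reason for this gain.

From the compounds shown here alone, whether fluoro or methoxy on this carbon, or a longer chain in place of this one, would keep such a low number remains open. So does whether the same change would act alike on the core of compound 1.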